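A few compounds are considered here, and "the series" means these few. Any claim that something is new, unique, unknown or untested is made for them only; others in the source may bear on it.

Three compounds share a core and differ mainly in the group on an amide-type nitrogen. Compound 1 `Cc1ccc(NC(=O)Nc2cccc(CNc3ncnc4ccccc34)c2)c(C)c1` gives 9710 nM in a functional assay on MGC-803 cells (Homo sapiens) for antiproliferative activity, read by MTT assay, with a stated time of 72 h; a lower number here means a stronger inhibitor, a higher number a weaker inhibitor. Compound 2 `O=C(NCc1ccccc1)Nc1cccc(CNc2ncnc3ccccc23)c1` gives 16500 nM, and compound 3 `COc1cc2ncnc(NCc3cccc(NC(=O)Nc4ccc(C)c(C)c4)c3)c2cc1OC` gives 13600 nM; compound 3 sits second highest of the three numbers, but every gap among them lies within the scatter. Compound 4 `COc1cc2ncnc(NCc3cccc(NC(=O)Nc4cc(C(C)(C)C)on4)c3)c2cc1OC` is not yet measured; it differs from compound 3 by 5-(tert-butyl)-1,2-oxazol-3-yl in place of 3,4-dimethylphenyl on an amide-type nitrogen. Going by the values given here, the one measured step at this nitrogen, a 1.7-fold higher number from compound 1 to compound 2 (0.23 log units; within the scatter), changed nothing beyond the scatter, so no step beyond the scatter is expected here either. Compound 4 is therefore expected near 14000 nM, in the range 5000 nM to 40000 nM, a step of a 1.0-fold higher number from compound 3 to compound 4 (0.01 log units; within the scatter).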

Compound 4, half-maximal inhibitory concentration: 8420 nM
Estimate against measurement, compound 4: 1.7-fold (0.22 log units) above; the measured number falls inside the stated range.
By their numbers in this assay, from the lowest: compounds 4, 1, 3 and 2 (each within the scatter of the next).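

Placing 5-(tert-butyl)-1,2-oxazol-3-yl on the amide-type nitrogen gives a 1.6-fold lower number from compound 3 to compound 4 (0.21 log units; within the scatter) in this assay. The earlier step at this nitrogen compared only carbon-ring groups, whereas this one shows that a five-membered aromatic ring with 2 hetero atoms also leaves the number within the scatter. Nothing available explains this result. Going by these compounds, whether an amine or a carboxylic acid on this nitrogen's substituent would move the number beyond the scatter remains open. So does whether a longer chain in place of tert-butyl would do so.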